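Switching the phenyl substituent of compound 2 to aminomethyl

The compounds below may be only part of what the source reports. "The series", "measured", "known", "first", "only" and "open" are said of these compounds alone.

Two compounds have been examined in an assay for inhibition of 15-hydroxyprostaglandin dehydrogenase [NAD(+)] (Homo sapiens), read by fluorescence, with a stated time of 15 min, in the presence of a further agent that is not named here; on this read-out lower numbers stand for stronger inhibition and higher numbers for weaker inhibition. Compound 1 `CCC[S+]([O-])c1sc2nc(-c3cccs3)cc(C(=O)O)c2c1N` gives 71 nM in this assay. Compound 2 `CCCC[S+]([O-])c1sc2nc(-c3nccs3)cc(-c3ccc(C(C)(C)O)cc3)c2c1N`, which carries a different chain on the sulfur, a different five-membered heteroaromatic ring and a substituted phenyl group in place of the acid, gives 3.6 nM in this assay. Among the measured compounds shown here, of the two numbers measured so far, compound 2 stands on the lower one, and the gap to compound 1 lies beyond the usual scatter of the measurement. The two compounds differ in several places at once. Nothing can be said about which of those changes carries the difference.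

Compound 3 `CCCC[S+]([O-])c1sc2nc(-c3nccs3)cc(-c3ccc(CN)cc3)c2c1N` has not yet been measured. It differs from compound 2 in one place: aminomethyl in place of 1-hydroxy-1-methylethyl on an aromatic carbon. The group that leaves and the group that enters each bring one hydrogen-bond donor and one hydrogen-bond acceptor, and both sit on an aromatic carbon of a six-membered aromatic ring of carbon only. For the measured compounds named here, with no comparable step among the measured compounds to lean on, the expectation for compound 3 rests on the closeness of the two groups in size and in donor and acceptor count, so a small step from compound 2 is expected, a 2.2-fold higher number from compound 2 to compound 3 (0.35 log units; beyond the scatter), with the direction uncertain and possibly within the scatter. Compound 3 is therefore expected to give about 8 nM in this assay, within a range from 2.5 nM to 25 nM.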

Compound 3, half-maximal inhibitory concentration: 11.5 nM
Compound 3: the middle estimate sits 1.4-fold (0.16 log units) below what was measured; the measured number falls inside the stated range.
By their numbers in this assay, from the lowest: compound 2; then compound 3; then compound 1.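

Among the compounds shown here, this is the first step that changes one place only, so it is the first reading of what the group on this aromatic carbon contributes. In this assay, aminomethyl in place of 1-hydroxy-1-methylethyl comes with a 3.2-fold higher number from compound 2 to compound 3 (0.50 log units; beyond the scatter), a modest step, which shows that the two groups are not interchangeable here even though each brings one hydrogen-bond donor and one hydrogen-bond acceptor and neither carries a net charge. No measurement is available that would explain this step.

Going by these compounds, the change swaps oxygen for nitrogen and also shortens the group from 4 heavy atoms to 2, and this single step cannot separate the two, so it remains open which of them goes with the higher number; a hydroxymethyl group or a 1-amino-1-methylethyl group on the same aromatic carbon would pull them apart. Also open, on these data alone, is how a carboxylic acid or a longer aminoalkyl chain would read at this place, and whether the step would keep its size with a different chain on the sulfur.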